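The compounds below may be only part of what the source reports. "The series", "measured", "known", "first", "only" and "open" are said of these compounds alone.

Both values below come from a functional assay on RAW264.7 cells (Mus musculus) for inhibition, read by ELISA, with a stated time of 24 h (on this read-out higher numbers stand for an effect only at larger amounts of compound and lower numbers for an effect already at smaller amounts), and form the whole measured record so far:

- compound 1 (`CC/C=C\C[C@H]1C(=O)C=C[C@H]1CC(=O)OCC`) gives 20000 nM in this test
- compound 2 (`CC/C=C\C[C@H]1C(=O)C=C[C@H]1CC(=O)OCCO`) gives 24000 nM in this test

For the measured compounds named here, the one measured step is (a 1.2-fold higher number from compound 1 to compound 2 (0.08 log units; within the scatter)). Going by the values given here, compound 2 therefore stands level with the only other measured compound.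

Next comes compound 3 (`CC/C=C\C[C@H]1C(=O)C=C[C@H]1CC(=O)OC(C)(C)C`), which has tert-butyl in place of 2-hydroxyethyl on an oxygen next to a carbonyl group. Among the compounds with values here, the only guide to this swap is that same step (a 1.2-fold higher number from compound 1 to compound 2 (0.08 log units; within the scatter)), which also altered the chain on this oxygen and stayed within the scatter. Within the data shown here, no measured compound carries tert-butyl, so the guide is thin, and a wide range is the honest choice. With that caution, no shift beyond the scatter is expected in this assay for this swap. The expected step is (a 1.2-fold lower number from compound 2 to compound 3 (0.08 log units; within the scatter)), an estimate and not a result. For compound 3 the estimated value is 20000 nM in the middle, with an expected range from 9000 nM to 45000 nM as its two ends.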

Compound 3, half-maximal effective concentration: 20000 nM
Beside the measured number, compound 3's estimate shows no gap at the digits printed; measured number inside the range.
By their numbers in this assay, from the lowest: compounds 1, 3 and 2 (each within the scatter of the next).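

In this assay the oxygen next to a carbonyl group now carries a third group, and putting tert-butyl in place of 2-hydroxyethyl gives a 1.2-fold lower number from compound 2 to compound 3 (0.08 log units; within the scatter), while putting tert-butyl in place of ethyl gives (no change at the digits printed from compound 1 to compound 3 (within the scatter)). This swap is a larger change than the earlier one: the 2-hydroxyethyl group that leaves has 3 heavy atoms, with 1 hydrogen-bond donor and 1 hydrogen-bond acceptor, whereas the tert-butyl group that enters has 4 heavy atoms, all carbon, with 0 of either, yet all three compounds remain within the scatter of one another. No separate measurement is available to explain why these three groups read alike.

As far as these compounds go, all three compounds keep the same carbonyl group and oxygen, so it remains open how a free carboxylic acid or an amide would read, and how a longer chain or a benzyl group on this oxygen would compare. Since no group shown here moves the number beyond the scatter, it is also still unknown whether any change at this place can do so.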